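A few compounds are considered here, and "the series" means these few. Any claim that something is new, unique, unknown or untested is made for them only; others in the source may bear on it.

Measured compounds so far:
compound 1 `O=C(NCc1cn(Cc2ccc(Cl)cc2)nn1)c1cn(-c2ccccc2)nc1-c1ccc(F)cc1` gives 210 nM in a functional assay on HeLa cells (Homo sapiens) for antiproliferative activity, read by sulforhodamine B assay, with a stated time of 48 h; a lower number here means a stronger inhibitor of growth, a higher number a weaker inhibitor of growth
compound 2 `COc1ccc(Cn2cc(CNC(=O)c3cn(-c4ccccc4)nc3-c3ccc(F)cc3)nn2)cc1OC` gives 200 nM in this assay
compound 3 `O=C(NCc1cn(Cc2ccc(Cl)cc2)nn1)c1cn(-c2ccccc2)nc1-c1ccc(Cl)cc1` gives 470 nM in this assay

Compound 3 carries the highest of the three numbers. Its nearest neighbour is compound 1, reached by the change a 2.2-fold higher number from compound 1 to compound 3 (0.35 log units; beyond the scatter), a modest step that lies beyond the scatter. Against compound 2 no single-change step is shown; its value simply stands lower than that of compound 3.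

Compound 4 `COc1ccc(Cn2cc(CNC(=O)c3cn(-c4ccccc4)nc3-c3ccc(Cl)cc3)nn2)cc1OC` is the next member. It differs from compound 3 in one place: 3,4-dimethoxyphenyl in place of 4-chlorophenyl on a saturated chain carbon bound to an aromatic nitrogen. The same change has been seen once already in this series, as a 1.1-fold lower number from compound 1 to compound 2 (0.02 log units; within the scatter), a step that stayed within the scatter. Nothing else among the measured compounds bears on this exchange; the pair that differs by the halogen on the aromatic carbon says nothing about the benzyl side.

Among the measured compounds shown here, with only one precedent, and that one flat, the expectation for compound 4 is that it sits close to compound 3, with no step beyond the scatter in this assay. The expected step is a 1.0-fold lower number from compound 3 to compound 4 (0.02 log units; within the scatter). Compound 4 is therefore estimated at 450 nM, within a range of 220 nM to 950 nM.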

Compound 4, concentration for 50% growth inhibition: 200 nM
Compound 4: middle estimate off by 2.3-fold (0.35 log units), on the high side; the whole stated range lies above it.
By their numbers in this assay, from the lowest: compounds 2, 4 and 1 (each within the scatter of the next); then compound 3.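

On a saturated chain carbon bound to an aromatic nitrogen, 3,4-dimethoxyphenyl in place of 4-chlorophenyl is not always a flat change: in this assay the core carrying the chloro group gives a 2.4-fold lower number from compound 3 to compound 4 (0.37 log units; beyond the scatter), a step that passes the scatter, which the earlier pair with the fluoro group did not. Even so, the two readings of this change do not show that its size depends on the core: the same change on two cores in this assay, a 1.1-fold lower number (0.02 log units; within the scatter) from compound 1 to compound 2 and a 2.4-fold lower number (0.37 log units; beyond the scatter) from compound 3 to compound 4, 2.2-fold (0.35 log units) apart, within the scatter of two such steps. The exchange of chloro for fluoro on an aromatic carbon now also has a second reading, no change at the digits printed from compound 2 to compound 4 (within the scatter), and this flat step does not separate from the earlier one either: the same change on two cores in this assay, a 2.2-fold higher number (0.35 log units; beyond the scatter) from compound 1 to compound 3 and no change at the digits printed (within the scatter) from compound 2 to compound 4, 2.2-fold (0.35 log units) apart, within the scatter of two such steps.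

Open, as far as these compounds go, is whether an amine or a carboxylic acid in place of the 4-chlorophenyl or 3,4-dimethoxyphenyl group would move the number beyond the scatter, and whether a longer chain between that ring and the aromatic nitrogen would do so. With only two halogens and two benzyl groups shown, it also remains open whether bromo on the aromatic carbon, or a single methoxy on the benzyl ring, would follow either reading.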